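Swapping 2-(trifluoromethyl)benzyl for 3-iodobenzyl on compound 1

The source may hold more compounds than are shown below. What is called first, only, known or untested is meant among the compounds shown, and "the series" means these compounds.

In a functional assay on LoVo cells (Homo sapiens) for cytotoxicity, read by MTT assay (a higher number here means a weaker inhibitor, a lower number a stronger inhibitor), compound 1 `Oc1ccc(CN(Cc2ccccc2C(F)(F)F)Cc2ccc(O)c3ncccc23)c2cccnc12` gives 93 nM, level with compound 2 `Oc1ccc(CN(Cc2cccc(C(F)(F)F)c2)Cc2ccc(O)c3ncccc23)c2cccnc12` at 94 nM, while compound 3 `Oc1ccc(CN(Cc2cc(C(F)(F)F)cc(C(F)(F)F)c2)Cc2ccc(O)c3ncccc23)c2cccnc12` lies clearly lower at 10 nM. Compound 1 therefore sits at the high end of the three numbers, together with compound 2.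

The next comparison is compound 4 `Oc1ccc(CN(Cc2cccc(I)c2)Cc2ccc(O)c3ncccc23)c2cccnc12`, which differs from compound 1 as follows: 3-iodophenyl in place of 2-(trifluoromethyl)phenyl on a saturated chain carbon bound to an amine nitrogen. In short, 3-iodophenyl stands in place of 2-(trifluoromethyl)phenyl.

Within the data shown here, two measured steps bear on this. Exchanging 2-(trifluoromethyl)phenyl for 3-(trifluoromethyl)phenyl gave a 1.0-fold higher number from compound 1 to compound 2 (0.00 log units; within the scatter), which is no change beyond the scatter. Adding a second trifluoromethyl gave a 9.4-fold lower number from compound 2 to compound 3 (0.97 log units; beyond the scatter), but compound 4 has no such second group, so that gain is not expected to carry over. Among the measured compounds shown here, no iodo compound has been measured yet, which keeps the range wide.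

No shift beyond the scatter is expected, and the estimated step is a 1.2-fold lower number from compound 1 to compound 4 (0.07 log units; within the scatter). The estimate for compound 4 is 80 nM, with an expected range of 30 nM to 200 nM.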

Compound 4, half-maximal inhibitory concentration: 393 nM
For compound 4 the middle estimate is 4.9-fold (0.69 log units) below the measured one; measured number outside the range, above it.
By their numbers in this assay, from the lowest: compound 3; then compounds 1 and 2 (each within the scatter of the next); then compound 4.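

In this assay this position does not accept every group: iodo in place of trifluoromethyl gives a 4.2-fold higher number from compound 2 to compound 4 (0.62 log units; beyond the scatter) and the full exchange gives a 4.2-fold higher number from compound 1 to compound 4 (0.63 log units; beyond the scatter) beyond the scatter. The earlier pair showed only that 2-(trifluoromethyl)phenyl and 3-(trifluoromethyl)phenyl read alike; compound 2 and compound 4 now show that the identity of the group on the ring changes the number, even with both names carrying the 3 label. Nothing at hand explains this step.

On these data alone, whether the rise is particular to iodo or extends to other halogens remains open, and 3-chlorophenyl or 3-bromophenyl here would separate the two. A 3-methoxyphenyl or unsubstituted phenyl group would also show whether trifluoromethyl itself stands out in this series.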